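Extending the chain end from compound 3 to compound 4

This account rests on a few compounds, and the source may have more. Where it says the series, first, only, none or still open, it means among the compounds named here.

Measured so far in a functional assay on A549 cells (Homo sapiens) for antiproliferative activity, read by MTT assay, with a stated time of 48 h; a higher number here means a weaker inhibitor, a lower number a stronger inhibitor:
- compound 1 `CO/C=C(\C=C\c1ccc(OC)c(O)c1)c1cc(OC)c(OC)c(OC)c1` gives 1600 nM
- compound 2 `C=C(/C=C/c1ccc(OC)c(N)c1)c1cc(OC)c(OC)c(OC)c1` gives 137 nM
- compound 3 `CC=C(/C=C/c1ccc(OC)c(N)c1)c1cc(OC)c(OC)c(OC)c1` gives 247 nM

Compound 3 (247 nM) cannot be separated from compound 2 (137 nM) on these numbers, while compound 1 (1600 nM) stands beyond the scatter with the higher number.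

The next compound is compound 4 `CCC=C(/C=C/c1ccc(OC)c(N)c1)c1cc(OC)c(OC)c(OC)c1`, not yet measured. Its difference from compound 3 is methyl in place of hydrogen on a saturated chain carbon bound to a double-bonded chain carbon, which amounts to methyl to ethyl.

Going by the values given here, one measured step bears on this change, namely a 1.8-fold higher number from compound 2 to compound 3 (0.26 log units; within the scatter) and nothing larger. That step is also methyl in place of hydrogen, though on a double-bonded chain carbon rather than a saturated one, so it is a close but inexact guide. Compound 1 differs from compound 3 in more than one place and gives no single-change comparison. Among the compounds with values here, a single step is thin evidence, and no measured compound carries a chain longer than that of compound 3.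

In this assay no step beyond the scatter is therefore expected, with a slight drift towards a higher number at most. The expected step is a 1.2-fold higher number from compound 3 to compound 4 (0.08 log units; within the scatter) and stays within the scatter. Compound 4 is estimated at 300 nM (expected range 140 nM to 640 nM).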

Compound 4, half-maximal inhibitory concentration: 398 nM
The estimate for compound 4 lay 1.3-fold (0.12 log units) below the measured number, within the range that was stated.
By their numbers in this assay, from the lowest: compounds 2, 3 and 4 (each within the scatter of the next, the first and the last beyond it); then compound 1.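

In this assay the methyl to ethyl change on the saturated chain carbon gives a 1.6-fold higher number from compound 3 to compound 4 (0.21 log units; within the scatter), so this change alone cannot be told apart from repeat measurement. Against the hydrogen of compound 2, however, ethyl gives a 2.9-fold higher number from compound 2 to compound 4 (0.46 log units; beyond the scatter), and this modest step is the only single-place difference at this chain end that clears the scatter, so two steps that each stay within it add up to a separation only across the full change from hydrogen to ethyl. Nothing at hand speaks to the reason for this separation.

The compounds shown end at ethyl, leaving open whether a propyl group or a longer chain at this position would widen the separation from compound 2 or leave it as it stands. A branched chain such as isopropyl, or a chain end carrying a hydroxyl or an amine, would show whether the separation belongs to ethyl itself or to any group placed there.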